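The source may hold more compounds than are shown below. What is called first, only, known or untested is meant among the compounds shown, and "the series" means these compounds.

Measured compounds:
compound 1, `Clc1ccc(-c2nnc(COc3ccc(-c4ccccc4)cc3)o2)c(Cl)c1`, gives 57.6%
compound 2, `Sc1nnc(COc2ccc(-c3ccccc3)cc2)n1-c1ccc(Cl)cc1`, gives 18.2%
compound 3, `Sc1nnc(COc2ccc(-c3ccccc3)cc2)n1-c1ccc(Br)cc1`, gives 31.8%

All three were tested in a functional assay on the whole organism (strain Wistar) for inhibition, with Rattus norvegicus as the target, read by paw edema, with a stated time of 4 h, at a dose of 10 mg/kg by the oral route; on this read-out higher numbers stand for more inhibition at the one dose given (going by the name of the read-out) and lower numbers for less inhibition. Compound 3 stands second highest of the three numbers. Compound 2 lies below it, and the step of a number 13.6 percentage points higher from compound 2 to compound 3 (beyond the scatter) shows what bromo in place of chloro on an aromatic carbon did; compound 1 lies higher still.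

Compound 4, `Cc1ccc(-n2c(S)nnc2COc2ccc(-c3ccccc3)cc2)c(C)c1`, has not yet been measured in this assay. It differs from compound 3 in one place: 2,4-dimethylphenyl in place of 4-bromophenyl on an aromatic nitrogen. Among the measured compounds shown here, the only measured step touching the group on this ring nitrogen is the halogen swap between compound 2 and compound 3, and that step was modest. For the measured compounds named here, no measured step replaces a halogen with methyl groups, so the data give no direct guide to the present change. Going by the values given here, the expectation therefore rests on compound 3 itself and on the modest size of the one step seen at this position.

For compound 4 the expected step is a number 1.8 percentage points lower from compound 3 to compound 4 (within the scatter), that is, nothing clearly beyond the scatter. Compound 4 is estimated at 30% in this assay, with a range from 14% to 46%.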

Compound 4, a percentage reported as inhibition, in the whole organism at one dose (the size of the read-out at that dose, not a potency): 54.5%
The estimate for compound 4 lay 24.5 percentage points below the measured number; the measured number lies above the stated range.
By their numbers in this assay, from the lowest: compound 2; then compound 3; then compounds 4 and 1 (each within the scatter of the next).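

In this assay, among the compounds shown here, the group on the aromatic nitrogen proves able to do more than the halogen swap suggested: 2,4-dimethylphenyl in place of 4-bromophenyl gives a number 22.7 percentage points higher from compound 3 to compound 4 (beyond the scatter), and 2,4-dimethylphenyl in place of 4-chlorophenyl gives a number 36.3 percentage points higher from compound 2 to compound 4 (beyond the scatter), the only step at this position rated large. Among these three compounds, then, a halogen on the phenyl ring is not needed for inhibition at this dose, as the compound with two methyl groups and no halogen gives the highest number of the three. Nothing available explains the rise, so the reason for it stays unknown.

This change removes the halogen and brings in two methyl groups at once, so the compounds shown cannot tell whether one methyl group, both together, or the loss of the halogen accounts for the gain. As far as these compounds go, a plain phenyl, a 4-methylphenyl or a phenyl bearing a methoxy group or an amine on the ring nitrogen would help separate these possibilities, and the reach of the trend beyond these few compounds remains open.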